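Swapping acetamido for trifluoromethyl: what one step suggests

A few compounds are considered here, and "the series" means these few. Any claim that something is new, unique, unknown or untested is made for them only; others in the source may bear on it.

compound 1 `CCOc1ccc(Nc2c(-c3ccc(OC)cc3)c(=O)oc3cc(OC)ccc23)cc1` gives 24300 nM
compound 2 `COc1ccc(-c2c(Nc3ccc(NC(C)=O)cc3)c3ccc(OC)cc3oc2=O)cc1` gives 85800 nM

Going by the values given here, in a functional assay on MCF7 cells (Homo sapiens) for antiproliferative activity, read by MTT assay, with a stated time of 48 h (a lower number here means a stronger inhibitor, a higher number a weaker inhibitor), compound 2 gives 85800 nM and so holds the higher of the two numbers measured so far, which marks it as the weaker inhibitor of the pair. Compound 3 `COc1ccc(-c2c(Nc3cccc(C(F)(F)F)c3)c3ccc(OC)cc3oc2=O)cc1` changes one group on the shared core, with 3-(trifluoromethyl)phenyl in place of 4-acetamidophenyl on a nitrogen on an aromatic ring and nothing else altered. Among the compounds with values here, only one measured step bears on this, and it is modest: a 3.5-fold higher number from compound 1 to compound 2 (0.55 log units; beyond the scatter) came with acetamido in place of ethoxy on an aromatic carbon. The acetamido group leaves again in the new change, so compound 1, which has none, is the nearest guide with its 24300 nM as a reference point. Within the data shown here, no measured compound carries a trifluoromethyl group, so this guide is weak. A modest drop is therefore expected, with a 2.5-fold lower number from compound 2 to compound 3 (0.39 log units; beyond the scatter) as the estimated move in this assay for this swap. Compound 3 is expected near 35000 nM with 11000 nM to 110000 nM as the estimated range.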

Compound 3, half-maximal inhibitory concentration: 36200 nM
Beside the measured number, compound 3's estimate is 1.0-fold (0.01 log units) below it, within the range that was stated.
By their numbers in this assay, from the lowest: compounds 1 and 3 (each within the scatter of the next); then compound 2.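

In this assay, the change on the nitrogen gives a 2.4-fold lower number from compound 2 to compound 3 (0.37 log units; beyond the scatter), and a second change at the same place, 3-(trifluoromethyl)phenyl in place of 4-ethoxyphenyl, gives a 1.5-fold higher number from compound 1 to compound 3 (0.17 log units; within the scatter), which is within the scatter. Compound 2 therefore stands apart as the weakest inhibitor of the three, while compound 1 and compound 3 cannot be told apart here, although 4-ethoxyphenyl and 3-(trifluoromethyl)phenyl carry different groups on the ring. The 4-acetamidophenyl group counts a hydrogen-bond donor and the 3-(trifluoromethyl)phenyl group none, but nothing available explains the difference between compound 2 and compound 3.

Going by these compounds, three compounds give only a narrow view of this position, and whether a plain phenyl on the nitrogen, or a phenyl carrying an amine or a carboxylic acid, would match compound 1 and compound 3 or compound 2 remains open. On these data alone, it is also open whether a change at this position would have the same effect with other groups on the shared core, such as a hydroxyl in place of a methoxy.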